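Aryl group on the carbonyl carbon: compound 4

A few compounds are considered here, and "the series" means these few. Any claim that something is new, unique, unknown or untested is made for them only; others in the source may bear on it.

Three compounds of the series share one core and differ only in the aryl group attached to the carbonyl carbon. Compound 1 `COc1ccc(/C=C/c2cc(OC)cc(OC)c2/C=C/C(=O)c2ccccc2)cc1` carries phenyl there, and in a functional assay on A549 cells (Homo sapiens) for antiproliferative activity, read by MTT assay, with a stated time of 48 h (on this read-out lower numbers stand for stronger inhibition and higher numbers for weaker inhibition), compound 1 gives 3.9 ug/mL. Compound 2 `COc1ccc(/C=C/c2cc(OC)cc(OC)c2/C=C/C(=O)c2ccc(Cl)c(Cl)c2)cc1` carries 3,4-dichlorophenyl; in this assay compound 2 gives 5.9 ug/mL. Compound 3 `COc1ccc(/C=C/c2cc(OC)cc(OC)c2/C=C/C(=O)c2ccccc2C)cc1` carries 2-methylphenyl; in this assay compound 3 gives 5.9 ug/mL. Compound 2 thus stands level with compound 3, and the step of a 1.5-fold higher number from compound 1 to compound 2 (0.18 log units; within the scatter) lies within the scatter, as do no change at the digits printed from compound 2 to compound 3 (within the scatter) and a 1.5-fold higher number from compound 1 to compound 3 (0.18 log units; within the scatter).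

Compound 4 `COc1ccc(/C=C/c2cc(OC)cc(OC)c2/C=C/C(=O)c2ccc(OC)cc2)cc1` is the next member and is not yet measured. Its change from compound 2: 4-methoxyphenyl in place of 3,4-dichlorophenyl on a carbonyl carbon. Going by the values given here, the steps that bear on it are the two other exchanges of the aryl group on the carbonyl carbon, a 1.5-fold higher number from compound 1 to compound 2 (0.18 log units; within the scatter) and no change at the digits printed from compound 2 to compound 3 (within the scatter), each within the scatter. Three aryl groups at this position have given numbers within the scatter of one another, so a fourth exchange is expected to do the same: the expected step of a 1.2-fold lower number from compound 2 to compound 4 (0.07 log units; within the scatter) is none beyond the scatter. Compound 4 is therefore estimated at 5 ug/mL, with a range from 2.5 ug/mL to 10 ug/mL.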

Compound 4, half-maximal inhibitory concentration: 4.5 ug/mL
The estimate for compound 4 lay 1.1-fold (0.05 log units) above the measured number; the measured number falls inside the stated range.
By their numbers in this assay, from the lowest: compounds 1, 4, 2 and 3 (each within the scatter of the next).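

In this assay, the hydrogen-bond acceptor that enters with 4-methoxyphenyl leaves the number within the scatter, with a 1.3-fold lower number from compound 2 to compound 4 (0.12 log units; within the scatter) and a 1.3-fold lower number from compound 3 to compound 4 (0.12 log units; within the scatter). Methoxy in place of hydrogen on the aryl group of compound 1 likewise stays within the scatter, with a 1.2-fold higher number from compound 1 to compound 4 (0.06 log units; within the scatter), so the four aryl groups shown on the carbonyl carbon (phenyl, 3,4-dichlorophenyl, 2-methylphenyl and 4-methoxyphenyl) cannot be separated in this assay, and no compound among them goes against this. No data are at hand to explain this lack of separation.

The compounds shown leave open whether an amine or a carboxylic acid on the aryl group, or a longer chain in place of methoxy, would move the number beyond the scatter. They also leave open whether exchanges elsewhere on the shared core, such as replacing the methoxy groups with hydroxy groups, would have a larger effect than those seen on the carbonyl carbon.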